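This account rests on a few compounds, and the source may have more. Where it says the series, first, only, none or still open, it means among the compounds named here.

In a physicochemical assay for solubility (a lower number here means a less soluble compound, a higher number a more soluble compound), compound 1 `Cc1nc(C)c(C(=O)NCC(=O)Oc2ccc(-c3cc(=O)c4c(O)c(O)c(O)cc4o3)cc2)nc1C` stands highest of the two measured compounds at 628 ug/mL, while compound 2 `Cc1nc(C)c(C(=O)N[C@H](CC(C)C)C(=O)Oc2ccc(-c3cc(=O)c4c(O)c(O)c(O)cc4o3)cc2)nc1C` gives 26 ug/mL. Compound 3 `Cc1nc(C)c(COC(=O)NCC(=O)Oc2ccc(-c3cc(=O)c4c(O)c(O)c(O)cc4o3)cc2)nc1C` differs from compound 1 as follows: (3,5,6-trimethylpyrazin-2-yl)methoxy in place of 3,5,6-trimethylpyrazin-2-yl on a carbonyl carbon, which is (3,5,6-trimethylpyrazin-2-yl)methoxy in place of 3,5,6-trimethylpyrazin-2-yl on a carbonyl carbon. Among the measured compounds shown here, the only measured step, the large 24-fold lower number from compound 1 to compound 2 (1.38 log units; beyond the scatter), puts isobutyl in place of hydrogen at a different place, so it bears only loosely on this change. A smaller fall in this assay is expected, an estimated 2.2-fold lower number from compound 1 to compound 3 (0.35 log units; beyond the scatter). For compound 3 the estimate is 280 ug/mL, with an expected range of 90 ug/mL to 650 ug/mL.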

Compound 3, solubility: 454 ug/mL
Compound 3: the middle estimate sits 1.6-fold (0.21 log units) below what was measured; the measured number falls inside the stated range.
By their numbers in this assay, from the lowest: compound 2; then compounds 3 and 1 (each within the scatter of the next).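

In this assay, among the compounds shown here, the first reading at this carbonyl carbon, whose other neighbour is an amide-type nitrogen, comes from putting (3,5,6-trimethylpyrazin-2-yl)methoxy in place of 3,5,6-trimethylpyrazin-2-yl, which gives a 1.4-fold lower number from compound 1 to compound 3 (0.14 log units; within the scatter). The larger group thus leaves the number within the scatter in this one pair, whereas the isobutyl change at the saturated chain carbon gave a 24-fold lower number from compound 1 to compound 2 (1.38 log units; beyond the scatter). No evidence is available to explain this result.

On these data alone, what an amine or a carboxylic acid would do on this carbonyl carbon remains open. So does whether isobutyl on the saturated chain carbon would give a comparable step in compound 3.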